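Swapping Bromo for Chloro in a Cytotoxicity Series

A few compounds are considered here, and "the series" means these few. Any claim that something is new, unique, unknown or untested is made for them only; others in the source may bear on it.

Compound 1, `Cc1ccc(Cn2cc(COc3ccc4c(=O)ccoc4c3)nn2)cc1`, gives 68500 nM in a functional assay on QGY7701 cells (Homo sapiens) for cytotoxicity, read by MTT assay, with a stated time of 48 h; a lower number here means a stronger inhibitor, a higher number a weaker inhibitor.
Compound 2, `O=c1ccoc2cc(OCc3cn(Cc4cccc(Br)c4)nn3)ccc12`, gives 17600 nM.
Compound 3, `CC(C)(C)c1ccc(Cn2cc(COc3ccc4c(=O)ccoc4c3)nn2)cc1`, gives only a limit of the assay, > 100000 nM.

Compound 2 stands lowest of the two numbers shown; its nearest neighbour is compound 1, and the step of a 3.9-fold lower number from compound 1 to compound 2 (0.59 log units; beyond the scatter) was a modest one beyond the scatter. The other measured step, an at least 1.4-fold higher number from compound 1 to compound 3 (0.16 log units; that floor lies within the scatter), stays within the scatter, with compound 3 sitting at the limit described in the limit of > 100000 nM in this assay, at which 1 of the 3 values shown sits.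

Compound 4, `O=c1ccoc2cc(OCc3cn(Cc4cccc(Cl)c4)nn3)ccc12`, is the next compound to be measured. It differs from compound 2 by chloro in place of bromo on an aromatic carbon. For the measured compounds named here, neither measured step exchanges one halogen for another, so the closest guide is only that compound 2 and compound 1 differ by a modest amount. A halogen-for-halogen swap of this kind is expected to give a change no larger than the scatter, if any, so compound 4 is estimated at 25000 nM, between 10000 nM and 60000 nM, meaning an expected step of a 1.4-fold higher number from compound 2 to compound 4 (0.15 log units; within the scatter).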

Compound 4, half-maximal inhibitory concentration: 28400 nM
The estimate for compound 4 lay 1.1-fold (0.06 log units) below the measured number; measured number inside the range.
By their numbers in this assay, from the lowest: compounds 2 and 4 (each within the scatter of the next); then compound 1. At a limit, above all of these: compound 3.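

At this place on the six-membered aromatic ring, the change of halogen gives a 1.6-fold higher number from compound 2 to compound 4 (0.21 log units; within the scatter), so in this assay the bromo and chloro compounds cannot be told apart. A second halogen also gives a lower number than the 4-methylphenyl group of the first compound: the swap to 3-chlorophenyl gives a 2.4-fold lower number from compound 1 to compound 4 (0.38 log units; beyond the scatter), a modest step that goes beyond the scatter, as the swap to 3-bromophenyl did. Nothing measured here offers a reason for these numbers.

Going by these compounds, it remains open whether the lower number follows from the halogen itself or from where it sits, as the 4-methylphenyl and 3-halophenyl groups differ in both at once. The compounds shown also leave open how an amine or a carboxylic acid on this same aromatic carbon would read.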